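This account rests on a few compounds, and the source may have more. Where it says the series, first, only, none or still open, it means among the compounds named here.

Working notes on the series. Compound 1 `COc1cc2c(Oc3ccc(NC(=O)NN4C(=O)CSC4c4c(F)cccc4F)cc3Cl)ccnc2cc1OCCCN1CCCC1` is recorded in a functional assay on MDA-MB-231 cells (Homo sapiens) for antiproliferative activity, read by MTT assay, with a stated time of 72 h (a higher number here means a weaker inhibitor, a lower number a stronger inhibitor), as "not determined" (no result reported). Compound 2 `COc1cc2c(Oc3c(F)cc(NC(=O)NN4C(=O)CCSC4c4c(F)cccc4F)cc3F)ccnc2cc1OCCCN1CCCC1` gives 9650 nM in this assay. Compound 3 `CCN1CCN(CCCOc2cc3nccc(Oc4c(F)cc(NC(=O)NN5C(=O)CSC5c5c(F)cccc5F)cc4F)c3cc2OC)CC1` gives 3100 nM in this assay, which is the lower of the two numbers recorded so far, with compound 2 as the nearest neighbour on the scale and the gap between the two lying beyond the scatter. Going by the values given here, no pair of measured compounds differs in a single place, so no step can be read off directly.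

Compound 4 `CCN(CC)CCCOc1cc2nccc(Oc3c(F)cc(NC(=O)NN4C(=O)CSC4c4c(F)cccc4F)cc3F)c2cc1OC` differs from compound 3 by diethylamino in place of 4-ethylpiperazin-1-yl on a saturated chain carbon, three bonds along the chain from an oxygen on an aromatic ring. Among the compounds with values here, with no measured step of this kind available, the expectation is a change of a 1.4-fold higher number from compound 3 to compound 4 (0.13 log units; within the scatter), roughly at the edge of the scatter. For compound 4 the estimate in this assay is 4200 nM, within a range of 1500 nM to 12000 nM.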

Compound 4, half-maximal inhibitory concentration: 3790 nM
Compound 4: middle estimate off by 1.1-fold (0.04 log units), on the high side; the measured number falls inside the stated range.
By their numbers in this assay, from the lowest: compounds 3 and 4 (each within the scatter of the next); then compound 2.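

Going by these compounds alone, the first single-place comparison, at the end of the 3-(4-ethylpiperazin-1-yl)propyl chain, gives a 1.2-fold higher number from compound 3 to compound 4 (0.09 log units; within the scatter) in this assay for diethylamino in place of 4-ethylpiperazin-1-yl. At this position, then, the ring and its second nitrogen can be replaced by the open-chain amine with no difference beyond the scatter in this read-out. Nothing at hand gives a reason for this result.

Still open, as far as these compounds go, is whether morpholin-4-yl at the same place would read alike. Also open, from the compounds shown here alone, is whether a shorter 2-(diethylamino)ethyl chain would keep the number in this range.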